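The source may report more compounds than this note shows. Statements on the series, on what has been measured and on what is new or still open speak of the compounds shown alone.

In a functional assay on HCT-15 cells (Homo sapiens) for inhibition, read by sulforhodamine B assay (on this read-out lower numbers stand for stronger inhibition of growth and higher numbers for weaker inhibition of growth), compound 1 (`O=C(CCC1=CCCN(Cc2ccc(F)cc2)C1=O)NO`) gives 9960 nM, the higher of the two actual numbers. Compound 2 (`O=C(CCC1=CCCN(CCCCc2cccc3ccccc23)C1=O)NO`), with a longer chain ending in a naphthyl group, gives 1670 nM, a gap beyond the scatter. Compound 3 (`Cc1ccccc1CN1CCC=C(CCC(=O)NO)C1=O`) reads > 10000 nM, which is a limit of the assay.

Compound 4 (`O=C(CCC1=CCCN(Cc2ccc([N+](=O)[O-])cc2)C1=O)NO`) keeps the core of compound 1 but carries nitro in place of fluoro on an aromatic carbon, para to a large group (nitro in place of fluoro on an aromatic carbon). Among the measured compounds shown here, only one measured step touches this aromatic group: a number no lower from compound 1 to compound 3 (the limit leaves the size open), where 2-methylphenyl stands in place of 4-fluorophenyl. For the measured compounds named here, its size cannot be read, so it gives no measure for the new change, and no step has been measured at this exact position. With compound 1 at 9960 nM as the only anchor, no shift beyond the scatter is expected in this assay.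

The expected change is a 1.1-fold lower number from compound 1 to compound 4 (0.04 log units; within the scatter). For compound 4 the estimated value is 9000 nM, with an expected range of 3500 nM to 20000 nM.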

Compound 4, concentration for 50% growth inhibition: > 10000 nM
Compound 4: no number, only a limit; the forecaster's own chance of this, stated with the estimate: 45%; at least 1.1-fold (0.04 log units) between middle value and limit.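

In this assay compound 4 reads > 10000 nM, which is a limit and not a number. Among the compounds shown here, this gives the first result for a change at this exact position: a number no lower from compound 1 to compound 4 (the limit leaves the size open). For the compounds shown here, neither this step nor the one from compound 1 to compound 3 can be read in size, so the aromatic group still has no measured shift. What the result adds is that nitro on this aromatic carbon brings no reading lower than that of compound 1, which gives 9960 nM. A second change on this aromatic ring ends at the same limit: the limit of > 10000 nM in this assay, at which 2 of the 4 values shown sit.

From the compounds shown here alone, what an amine or a carboxylic acid in place of fluoro on this carbon would read stays open. So does whether any change on this aromatic ring can give a number lower than that of compound 1.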